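The source may report more compounds than this note shows. Statements on the series, on what has been measured and on what is new or still open speak of the compounds shown alone.

Of the three compounds measured in a functional assay on CHO cells for inhibition of metabotropic glutamate receptor 5 (Rattus norvegicus), read by FLIPR and calcium flux (a lower number here means a stronger inhibitor, a higher number a weaker inhibitor), compound 3 `Cc1ccc2ccc(-c3cc(F)cc(C#N)c3)cc2n1` gives 0.8 nM, the lowest number of the set. Compound 1 `Cc1ccc2ccc(-c3cccc(CO)c3)cc2n1` gives 8700 nM and compound 2 `Cc1ccc2ccc(-c3ccccc3C#N)cc2n1` gives 9800 nM, and both of these gaps to compound 3 lie beyond the scatter. Compound 4 `CCSc1cc(C#N)cc(-c2ccc3ccc(C)nc3c2)c1` has not yet been measured. It differs from compound 3 by ethylsulfanyl in place of fluoro on an aromatic carbon. Among the measured compounds shown here, no step between measured compounds shows the effect of such a change, so the expectation rests on compound 3 alone. The step from compound 3 to compound 4 is expected to be a rise in the number, a 6.3-fold higher number from compound 3 to compound 4 (0.80 log units; beyond the scatter), somewhat beyond the scatter. Compound 4 is therefore estimated at 5 nM, with a range of 0.8 nM to 40 nM.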

Compound 4, half-maximal inhibitory concentration: 72 nM
Compound 4: the middle estimate sits 14-fold (1.16 log units) below what was measured, outside the stated range (above it).
By their numbers in this assay, from the lowest: compound 3; then compound 4; then compounds 1 and 2 (each within the scatter of the next).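

Among the compounds shown here, on the aromatic carbon meta to a cyano group, replacing fluoro with ethylsulfanyl in this assay gives a 90-fold higher number from compound 3 to compound 4 (1.95 log units; beyond the scatter), the first reading of any change at this position. The position is therefore sensitive to this exchange, and the larger group is accommodated only with a large rise in the number. The data shown offer no measurement that explains the size of this step. Whether the sulfur or the ethyl chain accounts for the rise remains open, and the compounds shown cannot tell how a methylsulfanyl or ethoxy group would read at this carbon.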